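Solubility notes: methoxy for fluoro on the aryl urea

A few compounds are considered here, and "the series" means these few. Any claim that something is new, unique, unknown or untested is made for them only; others in the source may bear on it.

Compound 1 `Cc1cc(NC(=O)Nc2ccccc2F)c2ccccc2n1` gives the highest number of the three measured in a physicochemical assay for solubility, at pH 7.4 (on this read-out lower numbers stand for lower solubility and higher numbers for higher solubility), at 3800 nM. Compound 3 `Cc1cc(NC(=O)Nc2ccc(F)cc2)c2ccccc2n1` sits essentially with it at 3700 nM, the step being a 1.0-fold lower number from compound 1 to compound 3 (0.01 log units; within the scatter). Compound 2 `Cc1cc(NC(=O)Nc2cccc(Cl)c2)c2ccccc2n1` is the outlier at 800 nM, with a 4.8-fold lower number from compound 1 to compound 2 (0.68 log units; beyond the scatter) and, from compound 2 to compound 3, a 4.6-fold higher number from compound 2 to compound 3 (0.67 log units; beyond the scatter).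

Compound 4 `COc1ccccc1NC(=O)Nc1cc(C)nc2ccccc12` differs from compound 1 by methoxy in place of fluoro on an aromatic carbon. Among the measured compounds shown here, no measured step exchanges a halogen for a methoxy, and no step changes the group at this ortho position; the measured steps only swap halogens and move them around the ring, with one of them leaving the number unchanged and one lowering it by a modest amount. For compound 4 the step is therefore expected to be small, within or near the scatter, with a wide range allowed in either direction: a 1.1-fold lower number from compound 1 to compound 4 (0.04 log units; within the scatter) is the estimated step. Compound 4 is estimated at 3500 nM, between 1200 nM and 9000 nM.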

Compound 4, solubility: 100 nM
Estimate against measurement, compound 4: 35-fold (1.54 log units) above, outside the stated range (below it).
By their numbers in this assay, from the lowest: compound 4; then compound 2; then compounds 3 and 1 (each within the scatter of the next).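

In this assay, methoxy in place of fluoro on this aromatic carbon, ortho to a large group, is a large change (a 38-fold lower number from compound 1 to compound 4 (1.58 log units; beyond the scatter)), and it is the biggest step yet seen in the series. The earlier steps shown here at this position only took fluoro away while the ring kept a halogen elsewhere, and one of them stayed within the scatter (a 1.0-fold lower number from compound 1 to compound 3 (0.01 log units; within the scatter)), so the flat result did not mean that this position tolerates any group. Nothing at hand bears on the reason for the drop.

On these data alone, whether the drop belongs to methoxy itself or to any group other than fluoro at this position stays open; methyl, hydroxyl or an amine there would help to separate these. Also open, as far as these compounds go, is whether methoxy gives a similar step elsewhere on the same ring.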